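Working notes: the trifluoromethyl-to-hydrogen step in this series

The source may report more compounds than this note shows. Statements on the series, on what has been measured and on what is new or still open speak of the compounds shown alone.

compound 1 `CNC(=O)c1cc(Oc2ccc(NC(=O)c3nccc(-c4ccc(OC)cc4)n3)cc2)ccn1`: 14200 nM
compound 2 `CNC(=O)c1cc(Oc2ccc(NC(=O)c3cc(-c4ccc(C(F)(F)F)cc4)ncn3)cc2F)ccn1`: > 100000 nM
compound 3 `CCc1ccc(-c2cc(C(=O)Nc3ccc(Oc4ccnc(C(=O)NC)c4)cc3)ncn2)cc1`: 29300 nM

In a functional assay on PC-3 cells (Homo sapiens) for cytotoxicity, read by MTT assay, with a stated time of 72 h (on this read-out lower numbers stand for stronger inhibition and higher numbers for weaker inhibition), compound 1 gives 14200 nM and compound 3 gives 29300 nM, two numbers within the scatter of each other. Compound 2 is reported only as a limit of the assay, > 100000 nM, at the limit of > 100000 nM in this assay, at which 1 of the 3 values shown sits. Going by the values given here, no measured step between compounds differing in one place exists here. Compound 4 `CNC(=O)c1cc(Oc2ccc(NC(=O)c3cc(-c4ccccc4)ncn3)cc2F)ccn1` arises from compound 2 through (hydrogen in place of trifluoromethyl on an aromatic carbon). Because compound 2 stands at the limit of > 100000 nM in this assay, at which 1 of the 3 values shown sits, the size of the step to compound 4 cannot be read from the numbers, and the direction can only be toward the measured range or staying at the limit. Compound 4 is expected to give 50000 nM, between 15000 nM and 150000 nM. The estimated step of an at least 2.0-fold lower number from compound 2 to compound 4 (0.30 log units; that floor lies within the scatter) is an expectation only.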

Compound 4, half-maximal inhibitory concentration: 44300 nM
Estimate against measurement, compound 4: 1.1-fold (0.05 log units) above; the range from low to high includes it.
By their numbers in this assay, from the lowest: compound 1; then compounds 3 and 4 (each within the scatter of the next). At a limit, above all of these: compound 2.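

In this assay, going by these compounds alone, this is the first one-place change that can be read: hydrogen in place of trifluoromethyl on this aromatic carbon gives an at least 2.2-fold lower number from compound 2 to compound 4 (0.35 log units; beyond the scatter). Compound 4, with a plain phenyl, gives a measured 44300 nM. Compound 2 is reported only as a limit, > 100000 nM, so the step sets a floor and its full size stays unknown: the limit of > 100000 nM in this assay, at which 1 of the 4 values shown sits.

Going by these compounds, whether the step carries over to the core of compound 1 remains open. Also open, on these data alone, is what an amine or a carboxylic acid on this aromatic carbon would give.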